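This account rests on a few compounds, and the source may have more. Where it says the series, first, only, none or still open, it means among the compounds named here.

In an ADME assay on microsomes from liver (Rattus norvegicus) for metabolic stability, read by LC-MS, in the presence of a further agent that is not named here (on this read-out higher numbers stand for fast clearance and lower numbers for slow clearance), three compounds sharing one core have been measured. Compound 1 `Cc1ncc(C)n2nc(-c3ccn4cc(-c5ccc(Br)cc5)nc4n3)nc12` gives 15 mL.min-1.g-1, compound 2 `Cc1ncc(C)n2nc(-c3ccn4cc(-c5ccccc5Br)nc4n3)nc12` gives 1.8 mL.min-1.g-1 and compound 3 `Cc1ncc(C)n2nc(-c3ccn4cc(-c5ccc(F)cc5)nc4n3)nc12` gives 3.1 mL.min-1.g-1. The two lower values sit close together, with a 1.7-fold higher number from compound 2 to compound 3 (0.24 log units; within the scatter), whereas the top value is clearly separated, with a 4.8-fold lower number from compound 1 to compound 3 (0.68 log units; beyond the scatter). Compound 3 therefore belongs to the low group of this small set. Compound 4 `COc1ccccc1-c1cn2ccc(-c3nc4c(C)ncc(C)n4n3)nc2n1` differs from it by a single change, 2-methoxyphenyl in place of 4-fluorophenyl on an aromatic carbon. Within the data shown here, no measured compound carries a methoxy group, so no step measures this change directly. The nearest evidence is the pair of modest steps away from the high value, an 8.3-fold lower number from compound 1 to compound 2 (0.92 log units; beyond the scatter) and a 4.8-fold lower number from compound 1 to compound 3 (0.68 log units; beyond the scatter), together with the small gap between their end points. Both aryl groups in the low group gave similar numbers, so the expected change is none beyond the scatter, with a 1.3-fold higher number from compound 3 to compound 4 (0.11 log units; within the scatter) as the estimated step. Compound 4 is estimated at 4 mL.min-1.g-1, with an expected range of 1.5 mL.min-1.g-1 to 11 mL.min-1.g-1.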

Compound 4, intrinsic clearance in microsomes: 9.1 mL.min-1.g-1
Compound 4: the middle estimate sits 2.3-fold (0.36 log units) below what was measured, and the stated range covers the measured number.
By their numbers in this assay, from the lowest: compounds 2 and 3 (each within the scatter of the next); then compounds 4 and 1 (each within the scatter of the next).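

In this assay, the aryl group at this position proves less interchangeable than the low group suggested: 2-methoxyphenyl in place of 4-fluorophenyl gives a 2.9-fold higher number from compound 3 to compound 4 (0.47 log units; beyond the scatter) and methoxy in place of bromo gives a 5.1-fold higher number from compound 2 to compound 4 (0.70 log units; beyond the scatter) on the same ring. A group at the 2-position of the phenyl ring therefore does not by itself go with a low number, as compound 2 and compound 4 differ beyond the scatter despite both carrying one. Compound 4 instead stands with compound 1, with a 1.6-fold lower number from compound 1 to compound 4 (0.22 log units; within the scatter) between them, so two quite different aryl groups now share the upper part of this set.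

The data offer no measurement that explains these differences. As far as these compounds go, it remains open how a 4-methoxyphenyl group, or a phenyl ring bearing an amine, would read at this position.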